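Removing a methyl from the cyclopropyl amide of compound 2

A few compounds are considered here, and "the series" means these few. Any claim that something is new, unique, unknown or untested is made for them only; others in the source may bear on it.

Of the compounds shown here, two have been measured in a physicochemical assay for lipophilicity, at pH 7.4; a lower number here means a more polar compound, a higher number a more lipophilic compound. Compound 1, `CNC(=O)c1cc(C(=O)NC2CC2)cc2c1O[C@H](CF)[C@H]2c1ccccc1`, gives 3.9 in this assay. Compound 2, `CNC(=O)c1cc(C(=O)N[C@H]2C[C@@H]2C)cc2c1OC[C@H]2c1ccccc1`, gives 4.5 in this assay, the higher of the two numbers, and its distribution coefficient lies beyond the scatter from that of compound 1. The two structures differ in more than one place, so their two values alone tell what they show.

Compound 3, `CNC(=O)c1cc(C(=O)NC2CC2)cc2c1OC[C@H]2c1ccccc1`, has not yet been measured in this assay. It differs from compound 2 in one place: hydrogen in place of methyl on a saturated ring carbon. Within the data shown here, no measured pair in the set shows this change, so the direction and size of the step cannot be read from the data; it must be estimated. With one carbon fewer on the three-membered ring, compound 3 is expected to come out somewhat lower than compound 2 in this assay, with the step estimated at a number 0.40 log units lower from compound 2 to compound 3 (beyond the scatter), a shift that may only just clear the scatter. Compound 3 is accordingly estimated at 4.1 in this assay, with a range from 3.7 to 4.5.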

Compound 3, distribution coefficient: 3.6
Compound 3: middle estimate off by 0.50 log units, on the high side; the measured number lies below the stated range.
By their numbers in this assay, from the lowest: compounds 3 and 1 (each within the scatter of the next); then compound 2.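

The methyl on the three-membered ring now has a step of its own: in this assay, going from 2-methylcyclopropyl to cyclopropyl gives a number 0.90 log units lower from compound 2 to compound 3 (beyond the scatter) and isolates a modest effect of that single carbon, which the first two compounds, differing in more than one place, could not show. Hydrogen in place of fluoromethyl on a saturated ring carbon of the shared core gives a number 0.30 log units lower from compound 1 to compound 3 (within the scatter), so compound 1 and compound 3 cannot be told apart in this assay, and that substitution has no resolved effect on this read-out. Nothing measured here explains the size of either step.

On these data alone, each step rests on a single pair of compounds, so it remains open whether the methyl step would have the same size on a different core or alongside the fluoromethyl group. As far as these compounds go, how a longer chain such as ethyl, or an amine, would read on the same saturated ring carbon of the three-membered ring also remains open.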